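The source may hold more compounds than are shown below. What is called first, only, known or untested is meant among the compounds shown, and "the series" means these compounds.

Compound 1 `O=C(NCc1ccc(CNS(=O)(=O)c2cccc(C(F)(F)F)c2)cc1)c1ccc(CNc2ncccn2)cc1` gives 1000 nM in an assay on MDA-MB-231 cells for binding affinity to C-X-C chemokine receptor type 4 (Homo sapiens), read by microscopy, with stated times of 10 min and 30 min; on this read-out lower numbers stand for an effect already at smaller amounts and higher numbers for an effect only at larger amounts of compound. Compound 2 `O=C(NCc1ccc(CNS(=O)(=O)c2ccc(-c3ccc(F)cc3)cc2)cc1)c1ccc(CNc2ncccn2)cc1` gives 1000 nM in this assay, so compound 2 stands level with compound 1 within the usual scatter of such measurements. Compound 3 `Cc1ccc(S(=O)(=O)NCc2ccc(CNC(=O)c3ccc(CNc4ncccn4)cc3)cc2)cc1` differs from compound 2 by methyl in place of 4-fluorophenyl on an aromatic carbon, the new group sitting on an aromatic carbon para to a large group. Among the measured compounds shown here, no measured pair here shows a step of this kind, and the two known values offer no difference to carry over. The expected step is no change at the digits printed from compound 2 to compound 3 (within the scatter), nothing beyond the scatter. Compound 3 is accordingly estimated at 1000 nM, with a range from 400 nM to 3000 nM.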

Compound 3, effective concentration (reported as EC, without a stated level of effect): 100 nM
Compound 3: middle estimate off by 10-fold (1.00 log units), on the high side; measured number outside the range, below it.
By their numbers in this assay, from the lowest: compound 3; then compounds 1 and 2 (each within the scatter of the next).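

The group carried on the sulfonyl sulfur can clearly shift the number in this assay. Methyl in place of 4-fluorophenyl gives a 10-fold lower number from compound 2 to compound 3 (1.00 log units; beyond the scatter), and 4-methylphenyl in place of 3-(trifluoromethyl)phenyl gives a 10-fold lower number from compound 1 to compound 3 (1.00 log units; beyond the scatter). Compounds 1 and 2, level with each other despite different aromatic groups there, gave no sign of such a shift. On these data alone, whether methyl itself matters stays open, since an ethyl, a methoxy or an amine in its place would be needed to tell. Nothing available here gives a reason for the lower number.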